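The compounds below may be only part of what the source reports. "The series", "measured", "known", "first", "only" and "open" are said of these compounds alone.

Measured in a functional assay on LOX IMVI cells (Homo sapiens) for cytotoxicity, read by MTT assay, with a stated time of 24 h; a higher number here means a weaker inhibitor, a lower number a stronger inhibitor:
compound 1 `O=S(=O)(NCCCNc1nccc(-c2[nH]c(-c3ccccc3)nc2-c2ccc(F)c(O)c2)n1)c1ccccc1`: 9580 nM
compound 2 `O=S(=O)(NCCCNc1nccc(-c2[nH]c(-c3ccccc3)nc2-c2ccc(F)c(O)c2)n1)c1ccc(F)cc1`: 19200 nM

Among the compounds with values here, compound 2, at 19200 nM, stands within the scatter of compound 1, its only neighbour on these numbers. Compound 3 `O=S(=O)(NCCCNc1nccc(-c2[nH]c(-c3ccccc3)nc2-c2ccc(Cl)c(O)c2)n1)c1ccc(F)cc1` has chloro in place of fluoro on an aromatic carbon, ortho to a hydroxy group and para to a large group: chloro in place of fluoro on an aromatic carbon. Within the data shown here, the one measured step, a 2.0-fold higher number from compound 1 to compound 2 (0.30 log units; within the scatter), puts fluoro in place of hydrogen elsewhere in the molecule, so it bears only indirectly. No change beyond the scatter is therefore expected in this assay. The estimated step is a 1.4-fold lower number from compound 2 to compound 3 (0.14 log units; within the scatter). Compound 3 is expected at 14000 nM, with an estimated range of 5500 nM to 36000 nM.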

Compound 3, half-maximal inhibitory concentration: 2300 nM
Estimate against measurement, compound 3: 6.1-fold (0.78 log units) above; measured number outside the range, below it.
By their numbers in this assay, from the lowest: compound 3; then compounds 1 and 2 (each within the scatter of the next).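

In this assay the halogen at this position counts: on the 4-fluoro-3-hydroxyphenyl ring, chloro in place of fluoro gives an 8.3-fold lower number from compound 2 to compound 3 (0.92 log units; beyond the scatter) and so moves the number beyond the scatter. The earlier step, a 2.0-fold higher number from compound 1 to compound 2 (0.30 log units; within the scatter) with fluoro in place of hydrogen elsewhere in the molecule, had shown no such change. Nothing available here accounts for the size of this step.

As far as these compounds go, whether bromo or methyl at this position would carry the change further remains open, as does whether a methoxy group in place of the hydroxy group would keep it.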